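Pyridin-2-yl in place of 4-(trifluoromethyl)phenyl on two cores

The source may hold more compounds than are shown below. What is called first, only, known or untested is meant among the compounds shown, and "the series" means these compounds.

Compound 1 `Cc1ccc(S(=O)(=O)Oc2ccc3c(c2C)[C@H](Cn2cc(-c4ccccn4)nn2)[C@@]24CC(=O)[C@@](C)(CC[C@@H]32)C4)cc1` reaches only the limit > 20000 nM in a functional assay on SW480 cells (Homo sapiens) for cytotoxicity, read by MTT assay, with a stated time of 4 days (on this read-out higher numbers stand for weaker inhibition and lower numbers for stronger inhibition), not a number.
Compound 2 `Cc1ccc(S(=O)(=O)Oc2ccc3c(c2C)[C@H](Cn2cc(-c4ccc(C(F)(F)F)cc4)nn2)[C@@]24CC(=O)[C@@](C)(CC[C@@H]32)C4)cc1` likewise reaches only the limit > 20000 nM in this assay.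
Compound 3 `C=C1C[C@]23C[C@@]1(O)CC[C@H]2c1ccc(OS(=O)(=O)c2ccc(C)cc2)c(C)c1[C@@H]3Cn1cc(-c2ccc(C(F)(F)F)cc2)nn1` also reaches only the limit > 20000 nM in this assay.

The change from compound 2 to compound 1 is pyridin-2-yl in place of 4-(trifluoromethyl)phenyl on an aromatic carbon. Its effect on this read-out is a step that the two limits leave unreadable from compound 2 to compound 1, because the limit of > 20000 nM in this assay, at which 3 of the 3 values shown sit, holds both values. Compound 4 `C=C1C[C@]23C[C@@]1(O)CC[C@H]2c1ccc(OS(=O)(=O)c2ccc(C)cc2)c(C)c1[C@@H]3Cn1cc(-c2ccccn2)nn1`, not yet measured, carries the same change on the core of compound 3: pyridin-2-yl in place of 4-(trifluoromethyl)phenyl on an aromatic carbon. The difference between the core of compound 2 and the core of compound 3 is not broken down here.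

Since the same kind of change left compound 1 at a limit, and compound 3 already sits at the same limit, compound 4 is expected to show a step that the limit leaves unreadable from compound 3 to compound 4 in this assay. On that basis compound 4 is estimated at 30000 nM in this assay, with a range from 15000 nM to 100000 nM, and most likely only a limit will be reported.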

Compound 4, half-maximal inhibitory concentration: > 20000 nM
Compound 4 ended at the assay's limit (the forecaster's own chance of this, stated with the estimate: 85%); the middle value is on the limit's open side.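

The step from compound 3 to compound 4 cannot be read, because a limit, not a number, holds both values: the limit of > 20000 nM in this assay, at which 4 of the 4 values shown sit.

The compounds shown leave open how far each lies past that limit, and so whether pyridin-2-yl in place of 4-(trifluoromethyl)phenyl, or the difference between the two cores, changes the result in this assay at all.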